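The source may report more compounds than this note shows. Statements on the series, on what has been measured and on what is new or still open speak of the compounds shown alone.

Measured so far: compound 3 `CC(C)(C)C(=O)NCCCCCN1CCN(c2ccc(Cl)cc2)CC1` gives 126 nM in an assay on HEK293 cells for binding affinity to D(4) dopamine receptor (Homo sapiens), read by radioligand binding; a higher number here means a weaker inhibitor, a lower number a stronger inhibitor; compound 1 `CC(C)(C)C(=O)NCCCCN1CCN(c2ccccc2Cl)CC1` gives 79.4 nM; compound 2 `CC(C)(C)C(=O)NCCCCN1CCN(c2ccc(Br)cc2)CC1` gives 31.6 nM.

Compound 3 has the highest of these three numbers, but its gap to compound 1 lies within the scatter, while compound 2 stands clearly lower. Compound 4 `CCC(C)(C)C(=O)NCCCCN1CCN(c2ccc(Cl)cc2)CC1` differs from compound 3 in one respect: ((1,1-dimethylpropyl)carbonyl)amino in place of (((tert-butyl)carbonyl)amino)methyl on a saturated chain carbon, four bonds along the chain from an amine nitrogen in a ring. Within the data shown here, the only single step measured, a 2.5-fold lower number from compound 1 to compound 2 (0.40 log units; beyond the scatter), changes the aryl halide and not this chain or amide, so no measured step bears directly on the change. Compound 4 carries the same aryl group as compound 3 with one chain atom moved onto the amide, so a step near the scatter is expected, a 2.1-fold lower number from compound 3 to compound 4 (0.32 log units; beyond the scatter); compound 4 is estimated at 60 nM, ranging from 20 nM to 180 nM.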

Compound 4, inhibition constant: 15.9 nM
The estimate for compound 4 lay 3.8-fold (0.58 log units) above the measured number; measured number below the stated range.
By their numbers in this assay, from the lowest: compounds 4 and 2 (each within the scatter of the next); then compounds 1 and 3 (each within the scatter of the next).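

In this assay, ((1,1-dimethylpropyl)carbonyl)amino in place of (((tert-butyl)carbonyl)amino)methyl gives a 7.9-fold lower number from compound 3 to compound 4 (0.90 log units; beyond the scatter) on a saturated chain carbon, four bonds along the chain from an amine nitrogen in a ring. The two compounds have the same atoms, joined differently, so this rearrangement alone moves the number beyond the scatter, something the earlier step in the aryl halide could not show. No measurement shown here accounts for this step.

As far as these compounds go, the chain and the amide end change together in this step, so their separate contributions remain open. Also open, from the compounds shown here alone, is how a longer chain ending in a carboxylic acid would read.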